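This account rests on a few compounds, and the source may have more. Where it says the series, first, only, none or still open, it means among the compounds named here.

Three compounds share one core and differ only at the far end of the chain. In a functional assay on 143B cells (Homo sapiens) for inhibition, read by MTT assay, with a stated time of 72 h (a lower number here means a stronger inhibitor, a higher number a weaker inhibitor), compound 1 `O=C(O)CCC(=O)OCCCCCCSc1ccc([N+](=O)[O-])c2nonc12` gives 2830 nM, compound 2 `O=C(CCC(=O)OCCCCCCSc1ccc([N+](=O)[O-])c2nonc12)Nc1ccccc1F` gives 3030 nM, and compound 3 `Cc1ccccc1NC(=O)CCC(=O)OCCCCCCSc1ccc([N+](=O)[O-])c2nonc12` gives 4660 nM. Compound 3 has the highest of the three numbers, yet its gaps to compound 2 and to compound 1 both lie within the scatter. Compound 4 `COc1ccc(NC(=O)CCC(=O)OCCCCCCSc2ccc([N+](=O)[O-])c3nonc23)cc1OC` carries 3,4-dimethoxyphenyl in place of 2-methylphenyl on an amide-type nitrogen. The steps that already altered this end of the molecule bear on it: a 1.1-fold higher number from compound 1 to compound 2 (0.03 log units; within the scatter), a 1.6-fold higher number from compound 1 to compound 3 (0.22 log units; within the scatter) and a 1.5-fold higher number from compound 2 to compound 3 (0.19 log units; within the scatter). No step beyond the scatter is therefore expected in this assay, and compound 4 is estimated at 4500 nM, between 2300 nM and 9000 nM, which would mean a 1.0-fold lower number from compound 3 to compound 4 (0.02 log units; within the scatter).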

Compound 4, half-maximal inhibitory concentration: 2770 nM
Compound 4: the middle estimate sits 1.6-fold (0.21 log units) above what was measured; low and high end bracket the measured number.
By their numbers in this assay, from the lowest: compounds 4, 1, 2 and 3 (each within the scatter of the next).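

In this assay, 3,4-dimethoxyphenyl in place of 2-methylphenyl on the amide-type nitrogen gives a 1.7-fold lower number from compound 3 to compound 4 (0.23 log units; within the scatter) and sits equally close to the other two compounds (a 1.1-fold lower number from compound 2 to compound 4 (0.04 log units; within the scatter) and a 1.0-fold lower number from compound 1 to compound 4 (0.01 log units; within the scatter)). This position therefore accepts a larger ring group, one carrying hydrogen-bond acceptors that 2-methylphenyl lacks, without a step beyond the scatter. Nothing available explains this flat result.

Going by these compounds, whether a piperazine amide at this end would move the number beyond the scatter remains open. The same goes for a shorter chain linking it to the shared core.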